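The source may hold more compounds than are shown below. What is called first, only, known or untested is meant among the compounds shown, and "the series" means these compounds.

Measured compounds:
compound 1, `Nc1nc(S)nc2ccc(Sc3ccc4ccccc4c3)cc12` — 5.52
compound 2, `Cc1ccc2nc(N)nc(N)c2c1` — 5.66

The account concerns two measured compounds and one not yet measured. In an assay for inhibition of Dihydrofolate reductase (Homo sapiens) (on this read-out lower numbers stand for lower potency and higher numbers for higher potency (the scale is a negative logarithm)), compound 1 gives 5.52, the lower of the two numbers in hand, while compound 2 gives 5.66, a number that sits within the scatter of compound 1, so no order between them can be claimed. Within the data shown here, no step between measured compounds that differ in a single place is available.

Compound 3, `Nc1nc(O)nc2ccc(Sc3ccc4ccccc4c3)cc12`, shares the core of compound 1 and differs from it by one change: hydroxy in place of sulfanyl on an aromatic carbon. Because compound 1 stands at 5.52 and no comparable change has been measured, the expectation rests on that single point; a modest loss is expected, so that the step of a number 0.32 log units lower from compound 1 to compound 3 (beyond the scatter) is estimated to lie at the edge of the scatter. Compound 3 is therefore expected to give 5.2, with a range from 4.5 to 5.9.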

Compound 3, logarithm of the reciprocal of the active concentration, log(1/C): 5.77
Estimate against measurement, compound 3: 0.57 log units below; the range from low to high includes it.
By their numbers in this assay, from the lowest: compounds 1, 2 and 3 (each within the scatter of the next).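

In this assay, hydroxy in place of sulfanyl on the aromatic carbon between two ring nitrogen atoms gives a number 0.25 log units higher from compound 1 to compound 3 (within the scatter) and so does not separate the two compounds. Among these compounds, this is the only single-place comparison in hand, and it shows that, with the rest of the core of compound 1 held fixed, the exchange of sulfanyl for hydroxy at this position produces no step that can be told from the scatter. No measurement at hand says why the two groups read so closely alike.

The compounds shown leave open how this carbon responds to other groups, such as methoxy, chlorine or a carboxylic acid. They also leave open whether hydroxy and sulfanyl would stay this close if another part of the shared core were changed.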